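Compound 3 to compound 4: a tert-butoxycarbonyl exchange

The compounds below may be only part of what the source reports. "The series", "measured", "known", "first", "only" and "open" are said of these compounds alone.

In a toxicity assay on MT4 cells (Homo sapiens) for cytotoxicity, read by MTT assay, with a stated time of 7 days (on this read-out lower numbers stand for higher toxicity in this test and higher numbers for lower toxicity in this test), compound 3 `Cc1cc(C)cc(S(=O)(=O)c2c(C(=O)NC3CC4(CCN(Cc5n[nH]c(=O)n5C)CC4)C3)[nH]c3ccc(Cl)cc23)c1` gives 178000 nM. Compound 2 `Cc1cc(C)cc(S(=O)(=O)c2c(C(=O)NC3CC4(CCN(S(C)(=O)=O)C4)C3)[nH]c3ccc(Cl)cc23)c1` gives 205000 nM, which lies within the scatter of compound 3. Compound 1 `Cc1cc(C)cc(S(=O)(=O)c2c(C(=O)NC3CC4(C3)CN(S(C)(=O)=O)C4)[nH]c3ccc(Cl)cc23)c1` gives > 233000 nM in this assay, and this is a limit of the assay, not a number.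

Compound 4 `Cc1cc(C)cc(S(=O)(=O)c2c(C(=O)NC3CC4(CCN(C(=O)OC(C)(C)C)CC4)C3)[nH]c3ccc(Cl)cc23)c1` shares the core of compound 3 but carries tert-butoxycarbonyl on the amine nitrogen in a ring: a group of 7 heavy atoms (5 carbon, 2 oxygen; no ring) in place of a group of 8 heavy atoms (4 carbon, 3 nitrogen, 1 oxygen; one five-membered aromatic ring with 3 hetero atoms), on an amine nitrogen in a ring. Within the data shown here, no measured step covers this exchange. The only one available, an at least 1.1-fold lower number from compound 1 to compound 2 (0.05 log units; that floor lies within the scatter), concerns a different group, on an amide-type nitrogen, and it offers only indirect guidance. It does show that one change in the substituent left the read-out within the scatter. Resting on that step and on compound 3 at 178000 nM, only a small move toward a lower number is expected, without a firm claim that it will exceed the scatter. The expected step is a 1.6-fold lower number from compound 3 to compound 4 (0.21 log units; within the scatter). For compound 4 the estimated value in this assay is 110000 nM, with an expected range from 35000 nM to 240000 nM.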

Compound 4, half-maximal cytotoxic concentration: 133000 nM
Compound 4: middle estimate off by 1.2-fold (0.08 log units), on the low side, and the stated range covers the measured number.
By their numbers in this assay, from the lowest: compounds 4, 3 and 2 (each within the scatter of the next). At a limit, above all of these: compound 1.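

The exchange on the amine nitrogen in a ring gives the first step read at this position, and in this assay it comes to a 1.3-fold lower number from compound 3 to compound 4 (0.13 log units; within the scatter). The group that leaves holds a five-membered aromatic ring with 3 hetero atoms and 1 hydrogen-bond donor, while tert-butoxycarbonyl has no ring and 0 hydrogen-bond donors, yet the read-out does not separate the two, so neither the ring nor the donor is needed on this nitrogen for a value of this size. Compound 1 alone stands at a limit, which is not a number, and the values of the others can be read as numbers: the limit of > 233000 nM in this assay, at which 1 of the 4 values shown sits.

The compounds shown leave open how this position would read with a carboxylic acid, a primary amine or a longer carbon chain on the same nitrogen. Among these compounds, they also leave open whether any group at this place can move the read-out beyond the scatter, since the one step available here stays within it.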